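A Larger Substituent at the Oxime Carbon of Compound 1

This account rests on a few compounds, and the source may have more. Where it says the series, first, only, none or still open, it means among the compounds named here.

Two flavone ethers have so far been tested in a functional assay on SK-HEP1 cells (Homo sapiens) for antiproliferative activity; a lower number here means a stronger inhibitor of growth, a higher number a weaker inhibitor of growth. Compound 1 `CO/N=C(\C)COc1ccc2oc(-c3ccccc3)cc(=O)c2c1` gives 800000 nM in this assay, and compound 2 `O=c1cc(-c2ccccc2)oc2cc(OC/C(=N/O)c3ccccc3)ccc12` gives 2000000 nM in this assay. Compound 1 therefore holds the lower of the two numbers, and its gap to compound 2 lies beyond the usual scatter, so compound 1 is the stronger of the two, although both are very weak inhibitors of growth on this cell line.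

Compound 3 `CO/N=C(/COc1ccc2oc(-c3ccccc3)cc(=O)c2c1)c1ccc(OC)cc1` has not yet been measured. It differs from compound 1 in one place: 4-methoxyphenyl in place of methyl on a carbon with a double bond to nitrogen. Going by the values given here, no measured pair shows this change on its own, so its effect cannot be read from the data. Given that both known compounds sit at such high concentrations, the step from compound 1 to compound 3 is expected to be small, with no change beyond the scatter or a slight weakening, a 1.3-fold higher number from compound 1 to compound 3 (0.10 log units; within the scatter). Compound 3 is estimated at 1000000 nM, with a range from 400000 nM to 3000000 nM.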

Compound 3, concentration for 50% growth inhibition: 2000000 nM
For compound 3 the middle estimate is 2.0-fold (0.30 log units) below the measured one, and the stated range covers the measured number.
By their numbers in this assay, from the lowest: compound 1; then compounds 2 and 3 (each within the scatter of the next).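

The change of 4-methoxyphenyl in place of methyl on a carbon with a double bond to nitrogen can now be read on its own: in this assay it gives a 2.5-fold higher number from compound 1 to compound 3 (0.40 log units; beyond the scatter). This position therefore accepts a far larger group, with 8 heavy atoms and an aromatic ring entering where 1 heavy atom left, at the price of only a modest weakening, and this larger group brings no gain in growth inhibition over methyl. No measurement at hand offers an explanation for this weakening.

The compounds shown leave open whether the step belongs to the aromatic ring itself or to its methoxy group, a question that a plain phenyl at this carbon would help to separate. They also leave open whether any group here can lower the number rather than raise it, for instance an ethyl, which would test a modest increase over methyl, or an amine carried on the aromatic ring.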